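Exposure notes: from compound 1 to compound 3

This account rests on a few compounds, and the source may have more. Where it says the series, first, only, none or still open, it means among the compounds named here.

In an ADME assay on the whole organism (Rattus norvegicus, strain Wister-Han) for pharmacokinetics, read by LC-MS, at a dose of 3 mg/kg by the oral route (on this read-out higher numbers stand for higher exposure at the dose given and lower numbers for lower exposure), compound 1 (`Cc1ccncc1C(=O)N1CC(Oc2cncc(N3C(=O)c4ccc(Cl)cc4C3(C)C)c2)C1`) gives 1020 ng.h/mL and compound 2 (`CCS(=O)(=O)N1CCC(c2cncc(N3C(=O)c4ccc(Cl)cc4C3(C)C)c2)CC1`) gives 1470 ng.h/mL. For the measured compounds named here, these two numbers lie within the usual scatter of each other, so compound 1 stands level with the only other measured compound. Compound 3 (`CC1(C)c2cc(Cl)ccc2C(=O)N1c1cncc(OC2CN(C(=O)c3ncccc3Cl)C2)c1`) carries 3-chloropyridin-2-yl in place of 4-methylpyridin-3-yl on a carbonyl carbon. Going by the values given here, no measured pair isolates this change, so the data give no firm direction and no step beyond the scatter is expected. The estimated step is a 1.1-fold lower number from compound 1 to compound 3 (0.05 log units; within the scatter), a size expected to stay within the scatter. With so little measured, the estimate keeps a wide range. For compound 3 the expected value in this assay is 900 ng.h/mL, with an estimated range from 300 ng.h/mL to 2700 ng.h/mL.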

Compound 3, area under the concentration-time curve: 10800 ng.h/mL
For compound 3 the middle estimate is 12-fold (1.08 log units) below the measured one; the measured number lies above the stated range.
By their numbers in this assay, from the lowest: compounds 1 and 2 (each within the scatter of the next); then compound 3.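

On the carbonyl carbon attached to the amide-type ring nitrogen, the choice of pyridine group matters strongly in this assay: 3-chloropyridin-2-yl in place of 4-methylpyridin-3-yl gives an 11-fold higher number from compound 1 to compound 3 (1.02 log units; beyond the scatter) and sets compound 3 clearly apart from the earlier level. The two groups match in heavy-atom count, ring size, hydrogen-bond donors and acceptors, and net charge, so these counted features do not separate them. No available measurement explains the step.

Chlorine replaces methyl and the attachment point on the pyridine changes in the same step, leaving their separate contributions unresolved. A 3-methylpyridin-2-yl or a 4-chloropyridin-3-yl group on the same carbonyl carbon would divide the change into those two parts.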